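This account rests on a few compounds, and the source may have more. Where it says the series, first, only, none or still open, it means among the compounds named here.

Within the data shown here, compound 2 `CC[C@H](C)[C@@H](CN(C(=O)[C@@H]1C[C@H]1c1ccccc1)c1ccc(-c2ccccc2)cc1)NC(C)=O` gives the lowest number of the two measured in a functional assay for agonist activity at G protein-coupled receptor 88 (Homo sapiens), read by HTRF and cAMP accumulation (a lower number here means that less compound is needed, a higher number that more compound is needed for the effect), at 5.8 nM; its only neighbour, compound 1 `CC(C)C[C@H](N)CN(C(=O)[C@@H]1C[C@H]1c1ccccc1)c1ccc(-c2ccccc2)cc1`, gives 880 nM in this assay, and the step of a 150-fold lower number from compound 1 to compound 2 (2.18 log units; beyond the scatter) shows how far apart they lie. Compound 3 `CCC(C)CNCCN(C(=O)[C@@H]1C[C@H]1c1ccccc1)c1ccc(-c2ccccc2)cc1` has not yet been measured. Compared with compound 2 it carries ((2-methylbutyl)amino)methyl in place of 1-acetamido-2-methylbutyl on a saturated chain carbon bound to an amide-type nitrogen. Among the measured compounds shown here, the one step that bears on this change is a 150-fold lower number from compound 1 to compound 2 (2.18 log units; beyond the scatter), where the acetamido group and the branched chain entered together and the number fell sharply. Compound 3 gives up that acetamido group, loses both defined stereocentres and moves the amine out along the chain, so the gain seen in compound 2 is expected to be largely undone. Because compound 1 sits at 880 nM without the acetamido group, a number of similar size is expected for compound 3, estimated at 1000 nM with a range from 200 nM to 8000 nM, a step of a 170-fold higher number from compound 2 to compound 3 (2.24 log units; beyond the scatter).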

Compound 3, half-maximal effective concentration: 4.7 nM
Estimate against measurement, compound 3: 210-fold (2.33 log units) above; the measured number lies below the stated range.
By their numbers in this assay, from the lowest: compounds 3 and 2 (each within the scatter of the next); then compound 1.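

In this assay, the step of a 1.2-fold lower number from compound 2 to compound 3 (0.09 log units; within the scatter) shows that this position, on a saturated chain carbon bound to an amide-type nitrogen, can carry 2-((2-methylbutyl)amino)ethyl in place of 2-acetamido-3-methylpentyl, so neither the acetamido group nor the two defined stereocentres of compound 2 are required for a number of this size. The step of a 190-fold lower number from compound 1 to compound 3 (2.27 log units; beyond the scatter) separates two chains that both carry an amine and no acetamido group, so the large gap seen earlier cannot be credited to the acetamido group alone. The data offer no evidence on why these chains differ.

Going by these compounds, it remains open whether the amine nitrogen in the chain of compound 3 matters, which an ether oxygen or an all-carbon chain in its place would test. Also open, on these data alone, are the single stereoisomers of the 2-methylbutyl branch and an acetyl group on that nitrogen.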